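The compounds below may be only part of what the source reports. "The series", "measured", "known", "first", "only" and "open" are said of these compounds alone.

Compound 1 `CCn1ccc2cc(C(O)c3cc(OC)c(OC)c(OC)c3)ccc21` carries a free hydroxy group on the carbon that links its two ring systems. In a functional assay on HT-29 cells (Homo sapiens) for cytotoxicity, read by XTT assay, with a stated time of 72 h (on this read-out higher numbers stand for weaker inhibition and lower numbers for stronger inhibition), compound 1 gives > 1000 nM, which is a limit of the assay rather than a number. Compound 2 `CCn1ccc2cc(C(OC(C)=O)c3cc(OC)c(OC)c(OC)c3)ccc21` differs from compound 1 by one change, (acetyl in place of hydrogen on an oxygen on a saturated carbon). In this assay compound 2 gives > 1000 nM, again a limit. The step that the two limits leave unreadable from compound 1 to compound 2 therefore cannot be sized, because the limit of > 1000 nM in this assay, at which 3 of the 3 values shown sit, covers every value in this set.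

Compound 3 `CCn1ccc2cc(/C(=N\O)c3cc(OC)c(OC)c(OC)c3)ccc21` replaces the hydroxy-bearing carbon with an oxime; the difference between the two cores is not broken down here. In this assay compound 3 gives > 1000 nM, which is also a limit.

Compound 4 `CCn1ccc2cc(/C(=N\OC(C)=O)c3cc(OC)c(OC)c(OC)c3)ccc21` is the unmeasured member of the set, and it differs from compound 3 by acetyl in place of hydrogen on an oxygen. Going by the values given here, this is the same kind of change as the one from compound 1 to compound 2, though not the same: in the earlier pair the oxygen sits on a saturated carbon whose other neighbour is a saturated chain carbon, whereas in compound 3 the oxygen's other neighbour is a double-bonded nitrogen.

Since the earlier acetylation left compound 2 at the same limit as compound 1, the step is expected to be a step that the limit leaves unreadable from compound 3 to compound 4. Compound 4 is estimated to give 3000 nM in this assay, most likely reported as a limit once more, between 1000 nM and 20000 nM.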

Compound 4, half-maximal inhibitory concentration: > 1000 nM
Compound 4 gave a limit, no number; the forecaster's own chance of this, stated with the estimate: 80%; the middle value does not contradict the limit.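

Compound 3 and compound 4 each give only a limit in this assay, so the acetyl step between them cannot be read, because no value in this set is a number: the limit of > 1000 nM in this assay, at which 4 of the 4 values shown sit.

The compounds shown leave open how strongly any of compound 1, compound 2, compound 3 and compound 4 acts on these cells, and whether acetyl in place of hydrogen changes that at all.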